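The source may report more compounds than this note shows. Statements on the series, on what has been measured and on what is new or still open speak of the compounds shown alone.

Measured compounds:
- compound 1 `Nc1nc2cc(N3CCCC3)ccc2cc1-c1cc(Cl)cc(Cl)c1`: 1400 nM
- compound 2 `Nc1nc2cc(N3CCCCC3)ccc2cc1-c1cc(Cl)cc(Cl)c1`: 6800 nM
- compound 3 `Cn1cc(-c2cc3ccc(N4CCCC4)cc3nc2N)c2ccccc21`: 440 nM

Notes on the series. Compound 1 and compound 2 share one core; compound 3 carries another. In a toxicity assay on J774.A1 cells (Mus musculus) for cytotoxicity, read by SYBR Green assay, with a stated time of 1 h (on this read-out lower numbers stand for an effect already at smaller amounts and higher numbers for an effect only at larger amounts of compound), compound 1 gives 1400 nM, compound 2 gives 6800 nM and compound 3 gives 440 nM. The difference between the two cores is not broken down here; the values place compound 3 lowest of the three, with compound 1 nearest and compound 2 furthest.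

Within the first core, one change is measured: piperidin-1-yl in place of pyrrolidin-1-yl on an aromatic carbon. It produced a 4.9-fold higher number from compound 1 to compound 2 (0.69 log units; beyond the scatter).

Compound 4 `Cn1cc(-c2cc3ccc(N4CCCCC4)cc3nc2N)c2ccccc21` is not yet measured in this assay. It differs from compound 3 by piperidin-1-yl in place of pyrrolidin-1-yl on an aromatic carbon, the same change with the same place as from compound 1 to compound 2.

Among the compounds with values here, for compound 4 the step of a 4.5-fold higher number from compound 3 to compound 4 (0.66 log units; beyond the scatter) is expected, set beside the measured one, because a 4.9-fold higher number from compound 1 to compound 2 (0.69 log units; beyond the scatter) is the only instance of this change on record and the cores differ. Compound 4 is estimated at 2000 nM, with a range from 800 nM to 5000 nM.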

Compound 4, half-maximal effective concentration: 560 nM
Compound 4: the middle estimate sits 3.6-fold (0.55 log units) above what was measured; the measured number lies below the stated range.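

In this assay, piperidin-1-yl in place of pyrrolidin-1-yl on the core of compound 3 gives a 1.3-fold higher number from compound 3 to compound 4 (0.10 log units; within the scatter). The size of the step therefore does not carry over from the core of compound 1, and the two instances of the change differ: the same change on two cores in this assay, a 4.9-fold higher number (0.69 log units; beyond the scatter) from compound 1 to compound 2 and a 1.3-fold higher number (0.10 log units; within the scatter) from compound 3 to compound 4, 3.8-fold (0.58 log units) apart, beyond the scatter of two such steps

With one pair on each core, this shows that the step cannot be assumed to transfer between these two cores, but it does not show which part of the cores accounts for the difference or how the change would behave on a further core.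

The compounds shown leave open whether morpholin-4-yl or an open-chain dimethylamino group on the same aromatic carbon would follow the step seen on the core of compound 1 or the one seen on the core of compound 3. Also open, on these data alone, is whether the larger azepan-1-yl ring would separate the two cores further.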